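Methyl for hydrogen on the ring nitrogen of compound 2

The source may report more compounds than this note shows. Statements on the series, on what has been measured and on what is new or still open speak of the compounds shown alone.

Among the compounds with values here, compound 2 `O=c1oc(Nc2ccccc2I)nc2ccccc12` is the only member of the set with a number in an assay on isolated protein for inhibition of complement C1r subcomponent (Homo sapiens) (on this read-out lower numbers stand for stronger inhibition and higher numbers for weaker inhibition), where compound 2 gives 3500 nM. Compound 1 `Cc1cccc2nc(NC(C)C)oc(=O)c12` returns only a limit in this assay, compound 1 standing at > 62500 nM (the limit of > 62500 nM in this assay, at which 1 of the 2 values shown sits). Compound 3 `CN(c1nc2ccccc2c(=O)o1)c1ccccc1I` differs from compound 2 by methyl in place of hydrogen on a nitrogen on an aromatic ring. Within the data shown here, no measured pair of this kind exists in the set, so the size of the change is open; a step beyond the scatter towards weaker inhibition is expected in this assay, a 2.9-fold higher number from compound 2 to compound 3 (0.46 log units; beyond the scatter). Compound 3 is accordingly estimated at 10000 nM, within 3000 nM to 40000 nM.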

Compound 3, half-maximal inhibitory concentration: 1400 nM
The estimate for compound 3 lay 7.1-fold (0.85 log units) above the measured number; measured number below the stated range.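

In this assay, methyl in place of hydrogen on a nitrogen on an aromatic ring gives a change towards stronger inhibition, not weaker (a 2.5-fold lower number from compound 2 to compound 3 (0.40 log units; beyond the scatter)). For this pair, the hydrogen on this nitrogen is therefore not needed for inhibition, and this position accepts one added carbon. Nothing at hand accounts for the direction of this step.

Going by these compounds, whether an ethyl group, a longer chain or a benzyl group on this nitrogen would continue the change stays open. So does whether methyl has the same effect on cores carrying a group other than the iodophenyl of compound 2 and compound 3, such as a carboxylic acid on that ring.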